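Compound 2 to compound 4: a smaller amine ring

The compounds below may be only part of what the source reports. "The series", "measured", "known", "first", "only" and "open" are said of these compounds alone.

Values in an ADME assay on microsomes from liver (Homo sapiens) for metabolic stability (on this read-out higher numbers stand for fast clearance and lower numbers for slow clearance), each one a limit and not a number:
Compound 1 `Cc1cc2ncncc2cc1Nc1ncc2c(n1)n(C1CCOCC1)c(=O)n2C` gives > 200 mL.min-1.g-1 as a limit
Compound 2 `Cc1cc2ncccc2cc1Nc1ncc2c(n1)n(C1CCN(C)CC1)c(=O)n2C` gives < 4 mL.min-1.g-1 as a limit
Compound 3 `Cc1cc2nccnc2cc1Nc1ncc2c(n1)n(C1CCN(C)CC1)c(=O)n2C` gives < 4 mL.min-1.g-1 as a limit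

Compound 2 sits on the lower of the two limits seen in the series (the limit of < 4 mL.min-1.g-1 in this assay, at which 2 of the 3 values shown sit). Compound 1 sits on the upper one (the limit of > 200 mL.min-1.g-1 in this assay, at which 1 of the 3 values shown sits). Compound 2 therefore offers a limit as its starting point, with no exact number.

Compound 4 `Cc1cc2ncccc2cc1Nc1ncc2c(n1)n([C@@H]1CCN(C)C1)c(=O)n2C` carries 1-methylpyrrolidin-3-yl in place of 1-methylpiperidin-4-yl on an aromatic nitrogen and has one defined stereocentre. Among the compounds with values here, no measured pair differs in one place only, so the series gives no direct size for this change.

A small rise in this assay is expected, with the estimated step of an at least 1.2-fold higher number from compound 2 to compound 4 (0.09 log units; that floor lies within the scatter) staying close to the usual scatter. This expectation starts from compound 2 at < 4 mL.min-1.g-1 as its limit. Compound 4 is expected at 5 mL.min-1.g-1 in this assay, with an estimated range from 2 mL.min-1.g-1 to 14 mL.min-1.g-1 for the coming measurement.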

Compound 4, intrinsic clearance in microsomes in the Homo sapiens assay: < 4 mL.min-1.g-1
Compound 4 gave a limit, no number; the forecaster's own chance of this, stated with the estimate: 50%; middle value at least 1.2-fold (0.09 log units) from the limit.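

In the Homo sapiens assay compound 2 gives < 4 mL.min-1.g-1 as a limit, not a number. In the Homo sapiens assay compound 4 gives < 4 mL.min-1.g-1 as a limit, not a number. No step can be read between them. The compounds shown leave open whether 1-methylpyrrolidin-3-yl in place of 1-methylpiperidin-4-yl changes clearance at all, and by how much. In a physicochemical assay for lipophilicity, read by HPLC, using the shake flask method, measured as octanol-water partition, at pH 7.4 (on this read-out higher numbers stand for higher lipophilicity and lower numbers for lower lipophilicity), compound 2 gives 1.8 and compound 4 gives 1.2 as measured numbers.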